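Moving the Chlorine on the Benzyl Group: Compound 2 to Compound 4

The source may report more compounds than this note shows. Statements on the series, on what has been measured and on what is new or still open speak of the compounds shown alone.

The measurements come from an ADME assay on HEK293 cells (Homo sapiens) for cytotoxicity, read by MTT assay, with a stated time of 24 h; a lower number here means a stronger inhibitor, a higher number a weaker inhibitor. For compound 1, `Cc1ccc(/C=C2\CN(C(=S)SCc3cn(Cc4ccccc4F)nn3)C/C(=C\c3ccc(C)cc3)C2=O)cc1`, the entry there reads "not determined" (no result reported). Compound 2, `O=C1/C(=C/c2ccccc2F)CN(Cc2cn(Cc3ccccc3Cl)nn2)C/C1=C\c1ccccc1F`, gives 33200 nM. Compound 3, `Cc1ccc(/C=C2\CN(Cc3cn(Cc4ccccc4Cl)nn3)C/C(=C\c3ccc(C)cc3)C2=O)cc1`, gives 91500 nM. On these two numbers compound 2 stands lowest, and the gap to compound 3 lies beyond the usual scatter of repeated runs. Within the data shown here, no two of the measured compounds differ in just one place, so there is no single-point step to learn from.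

Compound 4, `O=C1/C(=C/c2ccccc2F)CN(Cc2cn(Cc3cccc(Cl)c3)nn2)C/C1=C\c1ccccc1F`, is the next candidate. It differs from compound 2 only in where the chlorine sits on the benzyl arm: 3-chlorophenyl in place of 2-chlorophenyl on a saturated chain carbon bound to an aromatic nitrogen. The atoms are the same and only their arrangement changes.

Among the measured compounds shown here, with no comparable step among the measured compounds, the expectation leans on the closeness of the two structures. In this assay a change of this kind is expected to give a step within the scatter, with no clear direction either way. Compound 4 is therefore estimated at 35000 nM, with a range from 12000 nM to 100000 nM. That estimate means a step of a 1.1-fold higher number from compound 2 to compound 4 (0.02 log units; within the scatter), expected to fall within the scatter.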

Compound 4, half-maximal inhibitory concentration: 33100 nM
Estimate against measurement, compound 4: 1.1-fold (0.02 log units) above; the range from low to high includes it.
By their numbers in this assay, from the lowest: compounds 4 and 2 (each within the scatter of the next); then compound 3.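

In this assay, among these compounds, the swap of 3-chlorophenyl in place of 2-chlorophenyl on a saturated chain carbon bound to an aromatic nitrogen gives a 1.0-fold lower number from compound 2 to compound 4 (0.00 log units; within the scatter) and is the only comparison so far in which a single place differs. Among the compounds shown here, on this pair, then, the two chlorine placements on the benzyl arm cannot be told apart, which the earlier compounds, differing in more than one place, could not show. No measured property is on hand that would explain this result.

On these data alone, this finding covers one pair on one core, so whether the swap from 2-chlorobenzyl to 3-chlorobenzyl would read the same on the core of compound 3 stays open. Also open, as far as these compounds go, is how the number would respond if a different group took the place of the chlorine on the benzyl arm, such as a methoxy group, a carboxylic acid or an amine, since a pair of chlorine placements says nothing about those groups.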